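A few compounds are considered here, and "the series" means these few. Any claim that something is new, unique, unknown or untested is made for them only; others in the source may bear on it.

Compound 1, `CCCCN(CC)Cc1c(C(F)(F)F)nc2n(-c3c(C)cc(C)cc3C)c(Cl)cn12`: 78 nM
Compound 2, `CCCCN(C)Cc1c(C(F)(F)F)nc2n(-c3c(C)cc(C)cc3C)c(Cl)cn12`: 310 nM
Compound 3, `Cc1cc(C)c(-n2c(Cl)cn3c(CN(C)Cc4ccco4)c(C(F)(F)F)nc23)c(C)c1`: 180 nM

All three were tested in an assay on cells for displacement of a labelled ligand from corticotropin-releasing factor receptor 1 (Homo sapiens), with a stated time of 100 min; on this read-out lower numbers stand for stronger inhibition and higher numbers for weaker inhibition. Compound 3 stands second highest of the three numbers there: its nearest neighbour is compound 2, which gives 310 nM, a gap within the usual scatter, while its furthest is compound 1, which gives 78 nM, a gap beyond the scatter.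

Compound 4, `Cc1cc(C)c(-n2c(Cl)cn3c(CN4CCC(C)CC4)c(C(F)(F)F)nc23)c(C)c1`, has not yet been measured. It differs from compound 3 at one place: 4-methylpiperidin-1-yl in place of ((furan-2-yl)methyl)(methyl)amino on a saturated chain carbon bound to an aromatic carbon. Every measured step here also changed what hangs on that amine nitrogen. The step of a 4.0-fold higher number from compound 1 to compound 2 (0.60 log units; beyond the scatter) and the step of a 2.3-fold higher number from compound 1 to compound 3 (0.36 log units; beyond the scatter) were both modest, and the step of a 1.7-fold lower number from compound 2 to compound 3 (0.24 log units; within the scatter) stayed within the scatter, so swapping these amine substituents has so far moved the numbers only a little. Among the measured compounds shown here, none of the measured steps closed the amine into a ring, so the direction for compound 4 is uncertain. Compound 4 is therefore expected to land near compound 3, with a step of a 1.4-fold lower number from compound 3 to compound 4 (0.14 log units; within the scatter) that may lie within the scatter. The estimate for compound 4 is 130 nM, within a range of 45 nM to 400 nM.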

Compound 4, inhibition constant: 3200 nM
For compound 4 the middle estimate is 25-fold (1.39 log units) below the measured one; the whole stated range lies below it.
By their numbers in this assay, from the lowest: compound 1; then compounds 3 and 2 (each within the scatter of the next); then compound 4.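

In this assay, among the compounds shown here, the amine on the saturated chain carbon bound to an aromatic carbon proves far less forgiving than the earlier compounds suggested: 4-methylpiperidin-1-yl in place of ((furan-2-yl)methyl)(methyl)amino gives an 18-fold higher number from compound 3 to compound 4 (1.25 log units; beyond the scatter) and is a large step. The same group in place of butyl(methyl)amino gives a 10-fold higher number from compound 2 to compound 4 (1.01 log units; beyond the scatter) and in place of butyl(ethyl)amino gives a 41-fold higher number from compound 1 to compound 4 (1.61 log units; beyond the scatter) so compound 4, the only one here with its amine nitrogen inside a ring, is the weakest of the four, while the three open-chain amines lie much closer together. Nothing available here explains this loss.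

The compounds shown leave open whether the loss goes with the closed ring itself or with its methyl group. A plain piperidine, a pyrrolidine or a morpholine at this place would help separate the two.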